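Urea series: solubility with trifluoromethoxy in place of tert-butyl

The source may report more compounds than this note shows. Statements on the series, on what has been measured and on what is new or still open speak of the compounds shown alone.

Of the compounds shown here, three have been measured in a physicochemical assay for solubility, at pH 7.4; on this read-out lower numbers stand for lower solubility and higher numbers for higher solubility. Compound 1 `Cc1cc(NC(=O)Nc2ccc(C(C)(C)C)cc2)c2ccccc2n1` gives 6200 nM in this assay, the highest of the three numbers. Compound 2 `Cc1cc(NC(=O)Nc2cnc3ccccc3c2)c2ccccc2n1` gives 400 nM in this assay, and compound 3 `Cc1cc(NC(=O)Nc2ccccc2C(N)=O)c2ccccc2n1` gives 200 nM in this assay; both gaps to compound 1 lie beyond the scatter. Within the data shown here, no two measured compounds differ in one place only, so no single-point step among measured compounds is available.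

Compound 4 `Cc1cc(NC(=O)Nc2ccc(OC(F)(F)F)cc2)c2ccccc2n1` differs from compound 1 at one place: trifluoromethoxy in place of tert-butyl on an aromatic carbon. The change sits on an aromatic carbon of a six-membered aromatic ring of carbon only. Among the measured compounds shown here, with no measured step to draw on, the expectation rests on compound 1 alone, which stands at 6200 nM in this assay. The expected step is a 1.2-fold lower number from compound 1 to compound 4 (0.09 log units; within the scatter), that is, nothing beyond the usual scatter in either direction. For compound 4 the estimated solubility in this assay is 5000 nM, with a range from 1500 nM to 15000 nM.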

Compound 4, solubility: 300 nM
The estimate for compound 4 lay 17-fold (1.22 log units) above the measured number; the whole stated range lies above it.
By their numbers in this assay, from the lowest: compounds 3, 4 and 2 (each within the scatter of the next); then compound 1.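

The series now has its first single-point step in this assay (a 21-fold lower number from compound 1 to compound 4 (1.32 log units; beyond the scatter)), large and beyond the scatter, for trifluoromethoxy in place of tert-butyl on an aromatic carbon para to a large group. The read-out at this position therefore depends strongly on the group it carries, which compounds 1, 2 and 3 could not show, since no two of them differ in one place only. Nothing measured here accounts for the size of this step.

Still open, on these data alone, is how other groups at this position compare with tert-butyl and trifluoromethoxy, for example an amine, a carboxylic acid or a methoxy group. Also open, as far as these compounds go, is whether the same exchange gives a step of similar size on other members.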